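The compounds below may be only part of what the source reports. "The series", "measured", "known", "first", "only" and "open" are said of these compounds alone.

Measured so far:
Compound 1 `O=C(COc1ccc2[nH]c(=O)c(-c3nccs3)c(CCc3ccccc3)c2c1)NC1(c2ccccc2)CC1` gives 4.5 nM in a functional assay on CHO cells for antagonist activity at adenosine receptor A2b (Homo sapiens), read by cAMP accumulation, with stated times of 15 min and 1 h; a lower number here means a stronger inhibitor, a higher number a weaker inhibitor.
Compound 2 `CC(C)(NC(=O)COc1ccc2[nH]c(=O)c(-c3ccccn3)c(CCc3ccccc3)c2c1)c1ccccc1` gives 504 nM in this assay.

Of these two numbers, compound 2 holds the higher one, and its distance from compound 1 is well beyond the scatter of this assay. The two differ at more than one point, so nothing can be read from them about any single change.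

Compound 3 `CC(C)(NC(=O)COc1ccc2[nH]c(=O)c(-c3cccnc3)c(CCc3ccccc3)c2c1)c1ccccc1` has not yet been measured. It keeps everything of compound 2 apart from one alteration: pyridin-3-yl in place of pyridin-2-yl on an aromatic carbon. The same atoms are present, joined differently.

Among the measured compounds shown here, no measured pair shows this particular change, so the size of the step from compound 2 to compound 3 is not anchored by any number in hand. In the absence of such a reference, the author expects a step of a 1.4-fold higher number from compound 2 to compound 3 (0.14 log units; within the scatter), which lies within the scatter, with the chance of a somewhat larger move in either direction. On that basis compound 3 is estimated to give 700 nM in this assay, within a range from 200 nM to 2500 nM.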

Compound 3, inhibition constant: 187 nM
Compound 3: the middle estimate sits 3.7-fold (0.57 log units) above what was measured, outside the stated range (below it).
By their numbers in this assay, from the lowest: compound 1; then compound 3; then compound 2.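

Pyridin-3-yl in place of pyridin-2-yl, on the aromatic carbon two atoms from the ring nitrogen, gives in this assay a 2.7-fold lower number from compound 2 to compound 3 (0.43 log units; beyond the scatter), a modest step but one beyond the scatter. Among the compounds shown here, this is the first reading of a single change at this position, and it shows that the position responds to how the pyridine is joined even though the two groups match in heavy atoms, hydrogen-bond donors and acceptors, and net charge. Nothing in hand accounts for the step.

As far as these compounds go, compound 1 differs from compound 2 and compound 3 at more than one point, so its gaps to them cannot be read as the result of any one change, and the share of its much lower number owed to the group at this position remains unknown. Also open, from the compounds shown here alone, is whether pyridin-4-yl or a plain phenyl at this position would extend the step, and whether the swap from pyridin-2-yl to pyridin-3-yl would have a similar size on the amide side chain of compound 1.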